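The source may report more compounds than this note shows. Statements on the series, on what has been measured and on what is new or still open speak of the compounds shown alone.

In an ADME assay on TZM cells (Homo sapiens) for cytotoxicity, with a stated time of 1 days (a higher number here means that more compound is tolerated, a lower number that less compound is tolerated), compound 1 `COCc1cc(N)c(Nc2ccc(C#N)cc2)cc1Oc1c(C)cc(CCC#N)cc1C` reports only a limit, > 200000 nM. Among the measured compounds shown here, compound 2 `CCOCc1cc(N)c(Nc2ccc(C#N)cc2)cc1Oc1c(C)cc(CCC#N)cc1C` gives 194000 nM, the only actual number so far. The result of compound 1 stays at a limit, (the limit of > 200000 nM in this assay, at which 1 of the 2 values shown sits). Compound 3 `Cc1cc(CCC#N)cc(C)c1Oc1cc(Nc2ccc(C#N)cc2)c(N)cc1Cl` carries chloro in place of ethoxymethyl on an aromatic carbon, chloro in place of ethoxymethyl on an aromatic carbon. For the measured compounds named here, the only measured step, an at least 1.0-fold lower number from compound 1 to compound 2 (0.01 log units; that floor lies within the scatter), altered that side chain without removing it, so it offers only a weak guide. A modest fall is expected, shown as a 1.8-fold lower number from compound 2 to compound 3 (0.25 log units; within the scatter). Compound 3 is estimated at 110000 nM, with an expected range from 35000 nM to 200000 nM.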

Compound 3, half-maximal cytotoxic concentration: 10400 nM
Compound 3: middle estimate off by 11-fold (1.02 log units), on the high side; measured number below the stated range.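

The step between the two ether side chains showed nothing beyond the scatter, but replacing the side chain with chloro on this aromatic carbon matters in this assay, with a 19-fold lower number from compound 2 to compound 3 (1.27 log units; beyond the scatter). Starting from methoxymethyl, the change is similarly large, with an at least 19-fold lower number from compound 1 to compound 3 (1.28 log units; beyond the scatter). That step is only a floor, since compound 1 reports a limit: the limit of > 200000 nM in this assay, at which 1 of the 3 values shown sits.

Going by these compounds, what remains open is whether losing the ether side chain or gaining chloro drives the fall. Hydrogen, fluoro, methyl or hydroxymethyl at this position would help separate those two readings.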